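A few compounds are considered here, and "the series" means these few. Any claim that something is new, unique, unknown or untested is made for them only; others in the source may bear on it.

Three compounds share one core and differ only in the group carried on the ring nitrogen. Compound 1 `C=C(Br)C(=O)Nc1ccc(/C=C2\SC(=O)N(Cc3ccc(C)cc3)C2=O)cc1` gives 3700 nM in a functional assay on CCRF-CEM cells (Homo sapiens) for cytotoxicity, read by cell counting, with a stated time of 3 days; on this read-out higher numbers stand for weaker inhibition and lower numbers for stronger inhibition. Compound 2 `C=C(Br)C(=O)Nc1ccc(/C=C2\SC(=O)N(Cc3ccccc3)C2=O)cc1` gives 2300 nM in this assay, and compound 3 `C=C(Br)C(=O)Nc1ccc(/C=C2\SC(=O)N(Cc3cccc(F)c3)C2=O)cc1` gives 3200 nM. Compound 2 holds the lowest of the three numbers, but every step that reaches it lies within the scatter: a 1.6-fold lower number from compound 1 to compound 2 (0.21 log units; within the scatter), and a 1.4-fold higher number from compound 2 to compound 3 (0.14 log units; within the scatter); likewise a 1.2-fold lower number from compound 1 to compound 3 (0.06 log units; within the scatter). On these numbers the three compounds cannot be told apart.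

Compound 4 `Nc1ccc(/C=C2\SC(=O)N(Cc3ccccc3)C2=O)cc1` is not yet measured. It differs from compound 2 at the other end of the molecule: hydrogen in place of (1-bromoethenyl)carbonyl on a nitrogen on an aromatic ring. For the measured compounds named here, none of the measured steps touches this place; all three concern the group on the saturated chain carbon bound to the amide-type nitrogen in the ring, and all three stayed within the scatter. Going by the values given here, the measured steps therefore give no guide to the size or direction of the change from compound 2 to compound 4, and the expectation must rest on the size of the structural change alone, which removes the only group of its kind.

For compound 4 a weaker result is expected, estimated at 20000 nM with a range from 4000 nM to 100000 nM, meaning an expected step of an 8.7-fold higher number from compound 2 to compound 4 (0.94 log units; beyond the scatter).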

Compound 4, half-maximal inhibitory concentration: 42000 nM
Compound 4: the middle estimate sits 2.1-fold (0.32 log units) below what was measured; measured number inside the range.
By their numbers in this assay, from the lowest: compounds 2, 3 and 1 (each within the scatter of the next); then compound 4.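

Taking the (1-bromoethenyl)carbonyl off the nitrogen on the aromatic ring, so that ((1-bromoethenyl)carbonyl)amino becomes amino, gives an 18-fold higher number from compound 2 to compound 4 (1.26 log units; beyond the scatter) in this assay, and this is the first step in the series to lie beyond the scatter. The three exchanges on the saturated chain carbon could not be told apart, whereas this position at the other end of the molecule carries a difference that the read-out separates clearly, and the size of the step marks the (1-bromoethenyl)carbonyl as a part of compound 2 that matters in these cells. Nothing available explains why the number rises so far on its removal.

The step removes the whole group at once, so the compounds shown do not separate what the bromine atom, the double bond and the carbonyl each contribute; a plain acetyl or a propenoyl without bromine on this nitrogen would address that. Going by these compounds, it also remains open whether the same step would appear with the 4-methylphenyl of compound 1 or the 3-fluorophenyl of compound 3 in place of the unsubstituted phenyl of compound 2.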